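Dechlorination of the thioamide series: expected stomach inhibition

The source may hold more compounds than are shown below. What is called first, only, known or untested is meant among the compounds shown, and "the series" means these compounds.

Among the compounds with values here, compound 2 `N=C(S)CCn1nc(-c2ccc(Cl)cc2)ccc1=O` stands highest of the two numbers measured so far; in a functional assay on the whole organism (stomach) for inhibition, with Rattus norvegicus as the target, at a dose of 100 mg/kg by the intraduodenal route (a higher number here means more inhibition at the dose given (going by the name of the read-out), a lower number less inhibition), compound 2 gives 42.5%. Compound 1 `N#CCCn1nc(-c2ccccc2)ccc1=O` in this assay gives 10.1%, a value lying below that of compound 2 by more than the scatter. Compound 3 `N=C(S)CCn1nc(-c2ccccc2)ccc1=O` differs from compound 2 as follows: hydrogen in place of chloro on an aromatic carbon. Within the data shown here, no measured pair shows this change on its own, so the expected step of a number 12.5 percentage points lower from compound 2 to compound 3 (beyond the scatter) is a modest loss, possibly none beyond the scatter. Compound 3 is therefore estimated at 30%, with a range from 12% to 50%.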

Compound 3, a percentage reported as inhibition, in the whole organism at one dose (the size of the read-out at that dose, not a potency): 53.7%
The estimate for compound 3 lay 23.7 percentage points below the measured number; the measured number lies above the stated range.
By their numbers in this assay, from the lowest: compound 1; then compound 2; then compound 3.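

In this assay the change from chloro to hydrogen gives a number 11.2 percentage points higher from compound 2 to compound 3 (beyond the scatter), so the chloro on the aromatic carbon is not required for inhibition at this dose. With hydrogen at that place, the thioamide in place of the nitrile gives a number 43.6 percentage points higher from compound 1 to compound 3 (beyond the scatter), which marks the chain end as a large contributor to the read-out. No measurement here accounts for either step.

From the compounds shown here alone, whether fluoro or methoxy at the aromatic carbon would match hydrogen remains open. So does the effect of a carboxylic acid, an amine or a longer chain at the chain end.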